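A few compounds are considered here, and "the series" means these few. Any claim that something is new, unique, unknown or untested is made for them only; others in the source may bear on it.

Measured compounds in a functional assay on NCI-H460 cells (Homo sapiens) for cytotoxicity, read by MTT assay, with a stated time of 72 h; a lower number here means a stronger inhibitor, a higher number a weaker inhibitor:

compound 1 `COc1cc2c(Oc3ccc(NC(=O)c4cc(-c5ccc(F)cc5)ccn4)cc3F)ccnc2cc1OCCCN1CCCCC1`: 250 nM
compound 2 `COc1cc2c(Oc3ccc(NC(=O)c4cc(-c5ccc(F)cc5)ccn4)cc3F)ccnc2cc1OCCCN1CCCC1`: 370 nM

Compound 1 holds the lower of the two numbers, but the step of a 1.5-fold higher number from compound 1 to compound 2 (0.17 log units; within the scatter) lies within the scatter, so the two compounds are not separated by this assay. That step concerns only the amine at the end of the saturated chain, pyrrolidin-1-yl in place of piperidin-1-yl, and leaves the rest of the shared core untouched.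

Compound 3 `COc1cc2c(Oc3ccc(NC(=O)c4cc(-c5ccccc5)ccn4)cc3F)ccnc2cc1OCCCN1CCCCC1` differs from compound 1 at the other end of the molecule: hydrogen in place of fluoro on an aromatic carbon. The change sits on the six-membered aromatic ring of carbon only, para to a large group, and read one bond further out it is 4-fluorophenyl to phenyl.

Among the compounds with values here, no measured step touches this ring, so there is nothing that bears directly on the change. A single fluorine removed from an aryl ring, with no ring, donor, acceptor or charge gained or lost, is taken as a change expected to stay within the scatter, with a modest widening of the range for the missing precedent. The expected step is a 1.2-fold higher number from compound 1 to compound 3 (0.08 log units; within the scatter). Compound 3 is therefore estimated at 300 nM, within 120 nM to 750 nM.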

Compound 3, half-maximal inhibitory concentration: 120 nM
Compound 3: middle estimate off by 2.5-fold (0.40 log units), on the high side, and the stated range covers the measured number.
By their numbers in this assay, from the lowest: compound 3; then compounds 1 and 2 (each within the scatter of the next).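

In this assay the change from 4-fluorophenyl to phenyl gives a 2.1-fold lower number from compound 1 to compound 3 (0.32 log units; beyond the scatter) and so, though modest, it lies beyond the scatter, unlike the change of amine at the far end of the chain, which gave a 1.5-fold higher number from compound 1 to compound 2 (0.17 log units; within the scatter) in the same assay. This aromatic carbon, para to a large group, is therefore a place where the assay registers a change as small as fluoro to hydrogen, with no ring, hydrogen-bond donor, hydrogen-bond acceptor or net charge entering or leaving, and here the compound without fluoro carries the lower number. No measurement at hand accounts for this step.

The compounds shown hold only fluoro and hydrogen on this carbon, so it remains open whether chloro, methoxy or an amine there would sit with compound 3, with compound 1 or elsewhere. Also open, going by these compounds, is whether the same step would appear with pyrrolidin-1-yl in place of piperidin-1-yl at the end of the chain, or with a longer chain carrying the amine.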